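The source may hold more compounds than are shown below. What is called first, only, known or untested is meant among the compounds shown, and "the series" means these compounds.

In a functional assay on MDA-MB-231 cells (Homo sapiens) for antiproliferative activity, read by MTT assay, with a stated time of 72 h (a higher number here means a weaker inhibitor, a lower number a stronger inhibitor), the measured compounds are:
- compound 1, `CS(=O)(=O)Nc1ccc(NC(=O)Nc2cccc(-c3nc(-c4ccc(NC(=O)c5cccnc5)cc4Cl)no3)c2)cc1Cl`, gives 600 nM
- compound 2, `CS(=O)(=O)Nc1ccc(NC(=O)Nc2cccc(-c3nc(-c4ccc(NC(=O)c5cccnc5)cc4Cl)no3)c2)cc1Br`, gives 700 nM
- compound 3, `CC(=O)Nc1ccc(NC(=O)Nc2cccc(-c3nc(-c4ccc(NC(=O)c5cccnc5)cc4Cl)no3)c2)cc1Cl`, gives only a limit of this assay, > 10000 nM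

Compound 4, `CC(=O)Nc1ccc(NC(=O)Nc2cccc(-c3nc(-c4ccc(NC(=O)c5cccnc5)cc4Cl)no3)c2)cc1Br`, is not yet measured in this assay. It differs from compound 3 by bromo in place of chloro on an aromatic carbon. The same change separates compound 1 from compound 2, (bromo in place of chloro on an aromatic carbon), and there it made a 1.2-fold higher number from compound 1 to compound 2 (0.07 log units; within the scatter). The surroundings are not identical: in the measured pair the aromatic carbon is ortho to a methanesulfonamido group, whereas in compound 3 and compound 4 it is ortho to an acetamido group, so this is the same kind of change rather than the same change. The two cores differ by acetyl in place of methylsulfonyl on a nitrogen on an aromatic ring, which gave an at least 16-fold higher number from compound 1 to compound 3 (1.22 log units; beyond the scatter) and an at least 14-fold higher number from compound 2 to compound 3 (1.15 log units; beyond the scatter), placing compound 3 at the limit of > 10000 nM in this assay, at which 1 of the 3 values shown sits.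

Compound 4 is therefore expected to remain at that limit, the estimated step being a step that the limit leaves unreadable from compound 3 to compound 4, because a 1.2-fold higher number from compound 1 to compound 2 (0.07 log units; within the scatter) was within the scatter. For compound 4 in this assay the estimate is 15000 nM, between 8000 nM and 40000 nM.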

Compound 4, half-maximal inhibitory concentration: 1000 nM
The estimate for compound 4 lay 15-fold (1.18 log units) above the measured number; measured number outside the range, below it.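

In this assay, bromo in place of chloro gave an at least 10-fold lower number from compound 3 to compound 4 (1.00 log units; beyond the scatter), and this did not match what the same change did on the other core: the same change on two cores in this assay, a 1.2-fold higher number (0.07 log units; within the scatter) from compound 1 to compound 2 and an at least 10-fold lower number (1.00 log units; beyond the scatter) from compound 3 to compound 4, at least 11-fold (1.06 log units) apart, beyond the scatter of two such steps. Acetyl in place of methylsulfonyl also depended on its surroundings, giving a 1.4-fold higher number from compound 2 to compound 4 (0.15 log units; within the scatter) with bromo present, while a 1.7-fold higher number from compound 1 to compound 4 (0.22 log units; within the scatter) likewise lies within the scatter: the same change on two cores in this assay, an at least 16-fold higher number (1.22 log units; beyond the scatter) from compound 1 to compound 3 and a 1.4-fold higher number (0.15 log units; within the scatter) from compound 2 to compound 4, at least 11-fold (1.06 log units) apart, beyond the scatter of two such steps. For compound 3, > 10000 nM is a limit of the assay, so the full size of these steps is not shown, and two cores give no general rule.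

The compounds shown leave open whether fluoro, iodo or methyl at that place would follow bromo or chloro. They also leave open whether a propanoyl group on the nitrogen would behave like acetyl.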